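A few compounds are considered here, and "the series" means these few. Any claim that something is new, unique, unknown or untested is made for them only; others in the source may bear on it.

Two chalcone-type compounds built on a shared core have been measured. Compound 1 `COc1ccc(C(=O)/C=C/c2cc(OC)c(OC)c(OC)c2)c2c1C=CC(C)(C)O2` and compound 2 `CCN(CC)c1ccc(/C=C/C(=O)c2ccc(OC)c3c2OC(C)(C)C=C3)cc1` differ only in the substitution of one aromatic ring. In a functional assay on SK-OV-3 cells (Homo sapiens) for antiproliferative activity, read by MTT assay, with a stated time of 24 h (a lower number here means a stronger inhibitor, a higher number a weaker inhibitor), compound 1 gives 9700 nM, whereas in this assay compound 2 gives 610 nM. Compound 2 therefore stands at the lowest of the two numbers, and its gap to compound 1 lies beyond the scatter. A third member, compound 3 `COc1ccc(C(=O)/C=C/c2ccc(O)cc2)c2c1C=CC(C)(C)O2`, has not yet been measured. It arises from compound 2 through a single change: hydroxy in place of diethylamino on an aromatic carbon. Going by the values given here, no single-site step between measured compounds is available for comparison, so the size of the effect is uncertain. A move toward a higher number in this assay is expected, probably beyond the scatter. The step is expected to be a 4.9-fold higher number from compound 2 to compound 3 (0.69 log units; beyond the scatter). Compound 3 is accordingly expected to give 3000 nM, within a range from 800 nM to 12000 nM.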

Compound 3, half-maximal inhibitory concentration: > 10000 nM
Compound 3 was reported as a limit; the forecaster's own chance of this, stated with the estimate: 5%; at least 3.3-fold (0.52 log units) between middle value and limit.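

In this assay compound 3 stands only as a limit, > 10000 nM. The result gives this aromatic carbon, para to a large group, its first single-site step: hydroxy in place of diethylamino brings an at least 16-fold higher number from compound 2 to compound 3 (1.21 log units; beyond the scatter), a large step beyond the scatter. Within this one pair, diethylamino goes with the lower number, but the change removes 5 heavy atoms, including a nitrogen, and adds a hydrogen-bond donor, and a single step cannot tell these differences apart.

The compounds shown leave open which part of diethylamino matters, a question that a simple amino group, dimethylamino, a pyrrolidine ring or a methoxy group on the same carbon would address. They also leave open whether the step would keep its size with any other substitution on the shared core.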